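Replacing the hydroxybutynyl arm with a sulfonamido-phenyl group

The compounds below may be only part of what the source reports. "The series", "measured", "known", "first", "only" and "open" are said of these compounds alone.

Of the compounds shown here, three sharing one core have been measured in an ADME assay (liver) for metabolic stability, with Liver microsome (Rattus norvegicus) as the target, using microsomes and NADPH, with a stated time of 30 min, tested at 1 uM; on this read-out higher numbers stand for fast clearance and lower numbers for slow clearance. Compound 1 `Nc1ccc(S(=O)(=O)N2CCN(c3ncc(C(O)(C(F)(F)F)C(F)(F)F)cc3Br)CC2)cn1` gives 32 mL.min-1.g-1, compound 2 `Nc1ccc(S(=O)(=O)N2CCN(c3ncc(C(O)(C(F)(F)F)C(F)(F)F)cc3C#CCCO)CC2)cn1` gives 68 mL.min-1.g-1, and compound 3 `Nc1ccc(S(=O)(=O)N2CCN(c3ncc(C(O)(C(F)(F)F)C(F)(F)F)cc3-c3cccc(F)c3)CC2)cn1` gives 52 mL.min-1.g-1. Compound 2 stands apart from compound 1 by a 2.1-fold higher number from compound 1 to compound 2 (0.33 log units; beyond the scatter), whereas its gap to compound 3, a 1.3-fold lower number from compound 2 to compound 3 (0.12 log units; within the scatter), lies within the scatter. Compound 4 `CS(=O)(=O)Nc1cccc(-c2cc(C(O)(C(F)(F)F)C(F)(F)F)cnc2N2CCN(S(=O)(=O)c3ccc(N)nc3)CC2)c1` has not yet been measured; it differs from compound 2 as follows: 3-(methanesulfonamido)phenyl in place of 4-hydroxybut-1-yn-1-yl on an aromatic carbon. Among the compounds with values here, the closest precedent is the step of a 1.3-fold lower number from compound 2 to compound 3 (0.12 log units; within the scatter), where an aryl group also replaced the hydroxybutynyl chain; a 1.6-fold higher number from compound 1 to compound 3 (0.21 log units; within the scatter) likewise stayed within the scatter. Compound 4 is therefore expected to show a 1.4-fold lower number from compound 2 to compound 4 (0.13 log units; within the scatter), no change beyond the scatter. The estimated value of compound 4 in this assay is 50 mL.min-1.g-1, with a range from 25 mL.min-1.g-1 to 100 mL.min-1.g-1.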

Compound 4, intrinsic clearance in microsomes: 81 mL.min-1.g-1
Compound 4: middle estimate off by 1.6-fold (0.21 log units), on the low side, within the range that was stated.
By their numbers in this assay, from the lowest: compounds 1, 3, 2 and 4 (each within the scatter of the next, the first and the last beyond it).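

In this assay, the larger 3-(methanesulfonamido)phenyl group leaves the clearance within the scatter of the 4-hydroxybut-1-yn-1-yl chain (a 1.2-fold higher number from compound 2 to compound 4 (0.08 log units; within the scatter)), and methanesulfonamido in place of fluoro on the phenyl ring also stays within it (a 1.6-fold higher number from compound 3 to compound 4 (0.19 log units; within the scatter)). Yet where 3-fluorophenyl did not clear the scatter against bromo, this aryl group does (a 2.5-fold higher number from compound 1 to compound 4 (0.40 log units; beyond the scatter)), so two quite different arms now lie beyond the scatter from compound 1. Nothing available explains these steps. Going by these compounds, whether an amine or a carboxylic acid on that phenyl ring, or a longer chain in place of the aryl group, would return the clearance towards that of compound 1 remains open.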